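The compounds below may be only part of what the source reports. "The series", "measured", "known", "first", "only" and "open" are said of these compounds alone.

Measured in a functional assay on HeLa cells (Homo sapiens) for inhibition; on this read-out lower numbers stand for stronger inhibition and higher numbers for weaker inhibition:
compound 1 `Oc1ccccc1-c1cc(-c2ccccc2C(F)(F)F)cc(-c2ccccc2O)n1`: 5800 nM
compound 2 `Oc1ccccc1-c1cc(-c2ccc(C(F)(F)F)cc2)cc(-c2ccccc2O)n1`: > 50000 nM, which is a limit of the assay and not a number
compound 3 `Oc1ccccc1-c1cc(-c2ccccc2OC(F)(F)F)cc(-c2ccccc2O)n1`: 9750 nM

Compounds 1 and 2 have the same atoms joined differently; the difference is 4-(trifluoromethyl)phenyl in place of 2-(trifluoromethyl)phenyl on an aromatic carbon. Across this change an at least 8.6-fold higher number from compound 1 to compound 2 (0.93 log units; beyond the scatter), with compound 2 standing at the limit of > 50000 nM in this assay, at which 1 of the 3 values shown sits. From compound 1 to compound 3 the change is trifluoromethoxy in place of trifluoromethyl on an aromatic carbon, and here a 1.7-fold higher number from compound 1 to compound 3 (0.23 log units; within the scatter).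

Compound 4 `Oc1ccccc1-c1cc(-c2ccc(OC(F)(F)F)cc2)cc(-c2ccccc2O)n1` has not yet been measured in this assay. It differs from compound 2 by trifluoromethoxy in place of trifluoromethyl on an aromatic carbon. This is the same kind of change as that from compound 1 to compound 3, not the same: in compound 3 the entering group is ortho to a large group, in compound 4 it is para to a large group. Beside the earlier step, a step that the limit leaves unreadable from compound 2 to compound 4 is expected, a step of about the same small size, resting on a 1.7-fold higher number from compound 1 to compound 3 (0.23 log units; within the scatter). Compound 4 is expected most likely to report only a limit again, resting on compound 2 at the limit of > 50000 nM in this assay, at which 1 of the 3 values shown sits. The estimate for compound 4 is 70000 nM, between 30000 nM and 200000 nM.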

Compound 4, half-maximal inhibitory concentration: > 50000 nM
Compound 4 gave a limit, no number (the forecaster's own chance of this, stated with the estimate: 75%); the middle value lies beyond the limit too.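

In this assay no step can be read between compound 2 and compound 4, because both values are limits and not numbers: the limit of > 50000 nM in this assay, at which 2 of the 4 values shown sit.

The compounds shown leave open whether trifluoromethoxy and trifluoromethyl differ at all in this assay when para to a large group.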